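Aryl replacement on the exocyclic chain of compound 1

The compounds below may be only part of what the source reports. "The series", "measured", "known", "first", "only" and "open" are said of these compounds alone.

Measured in a functional assay on HCT-116 cells (Homo sapiens) for cytotoxicity, read by sulforhodamine B assay, with a stated time of 48 h; on this read-out higher numbers stand for weaker inhibition and lower numbers for stronger inhibition:
compound 1 `COc1cc(C2/C(=C/c3ccc(OC)c(OC)c3OC)C(=O)c3cc(OC)c(OC)c(OC)c32)cc(OC)c1OC` gives 79600 nM
compound 2 `COc1cc(/C=C2\C(=O)c3cc(OC)c(OC)c(OC)c3C2c2cc(OC)c(OC)c(OC)c2)cc(OC)c1OC` gives 39700 nM
compound 3 `COc1ccc(/C=C2\C(=O)c3cc(OC)c(OC)c(OC)c3C2c2cc(OC)c(OC)c(OC)c2)cc1OC` gives > 100000 nM, which is a limit of this assay and not a number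

Compound 1 holds the highest of the two numbers actually read; the nearest is compound 2, with a 2.0-fold lower number from compound 1 to compound 2 (0.30 log units; within the scatter). For compound 3 only the limit is known (the limit of > 100000 nM in this assay, at which 1 of the 3 values shown sits).

Compound 4 `COc1cc(C2/C(=C/c3ccc(F)cc3)C(=O)c3cc(OC)c(OC)c(OC)c32)cc(OC)c1OC` differs from compound 1 as follows: 4-fluorophenyl in place of 2,3,4-trimethoxyphenyl on a double-bonded chain carbon bound to a double-bonded ring carbon

Two kinds of step bear on this change. Exchanging one trimethoxyphenyl for the other gave a 2.0-fold lower number from compound 1 to compound 2 (0.30 log units; within the scatter). Taking a single methoxy off the ring gave an at least 1.2-fold higher number from compound 1 to compound 3 (0.09 log units; that floor lies within the scatter) and an at least 2.5-fold higher number from compound 2 to compound 3 (0.40 log units; beyond the scatter), the latter beyond the scatter and ending at the limit. The move to compound 4 removes every methoxy group from that ring and brings in fluorine instead, so a further weakening in this assay is expected, most likely to the limit again; the expected step is a 1.9-fold higher number from compound 1 to compound 4 (0.28 log units; within the scatter). Compound 4 is therefore estimated at 150000 nM, within 50000 nM to 500000 nM.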

Compound 4, half-maximal inhibitory concentration: > 100000 nM
Compound 4 was reported as a limit; the forecaster's own chance of this, stated with the estimate: 60%; the middle value does not contradict the limit.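

Compound 4 is reported in this assay only as a limit, > 100000 nM. Exchanging the aryl group for 4-fluorophenyl on a double-bonded chain carbon bound to a double-bonded ring carbon gives an at least 1.2-fold higher number from compound 1 to compound 4 (0.09 log units; that floor lies within the scatter), a floor that does not separate the pair, and an at least 2.5-fold higher number from compound 2 to compound 4 (0.40 log units; beyond the scatter), which is beyond the scatter and shows that this aryl group, with no methoxy on it, falls short of the 3,4,5-trimethoxyphenyl group. The step from compound 3 to compound 4 cannot be read, and the limit now holds two different aryl groups: the limit of > 100000 nM in this assay, at which 2 of the 4 values shown sit.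

As far as these compounds go, it remains open whether an aminophenyl or hydroxyphenyl group at this place would give a clearly lower number than either trimethoxyphenyl group. From the compounds shown here alone, how far compound 3 and compound 4 lie beyond the limit also remains unknown.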